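From fluoro to bromo: estimating a half-life

This account rests on a few compounds, and the source may have more. Where it says the series, first, only, none or still open, it means among the compounds named here.

Compound 1 `Cc1cccc2c(-c3ccc4ccc(F)cc4n3)c[nH]c12`: 0.883 h
Compound 2 `Cc1cccc2c(-c3ccc4cccc(F)c4n3)c[nH]c12`: 0.983 h
Compound 3 `Cc1cccc2c(-c3ccc4c(O)cccc4n3)c[nH]c12`: 0.283 h

In an ADME assay on microsomes from liver (Homo sapiens) for metabolic stability, using NADPH, with a stated time of 40 min, tested at 2 uM (on this read-out higher numbers stand for a longer-lived compound and lower numbers for a shorter-lived compound), compound 2 gives 0.983 h. That places it within the usual scatter of compound 1 at 0.883 h, while compound 3 at 0.283 h lies lower, beyond the scatter. Compound 1 and compound 2 each carry a fluoro group, at different places on the shared core, whereas compound 3 carries a hydroxy group.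

The next compound to be tested, compound 4 `Cc1cccc2c(-c3ccc4cccc(Br)c4n3)c[nH]c12`, has bromo in place of fluoro on an aromatic carbon of compound 2 (bromo in place of fluoro on an aromatic carbon). Among the measured compounds shown here, no measured pair shows this swap, and no measured compound carries bromo, so the evidence is thin. In this assay, only a slight shortening of the half-life is expected, staying within the scatter. The expected step is a 1.3-fold lower number from compound 2 to compound 4 (0.12 log units; within the scatter). For compound 4, the estimated half-life is 0.75 h, with an expected range of 0.35 h to 1.5 h.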

Compound 4, half-life: 2.4 h
Beside the measured number, compound 4's estimate is 3.2-fold (0.51 log units) below it, outside the stated range (above it).
By their numbers in this assay, from the lowest: compound 3; then compounds 1 and 2 (each within the scatter of the next); then compound 4.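

At this place on the shared core, an aromatic carbon of a six-membered aromatic ring of carbon only, the choice of halogen matters: in this assay, bromo in place of fluoro gives a 2.4-fold higher number from compound 2 to compound 4 (0.39 log units; beyond the scatter). The earlier compounds shown here could not show this, as no two of them carry different groups at the same place. Nothing shown here explains the step, so the data record the change in half-life but not its cause.

Among the compounds shown here, it remains open whether the half-life would follow the same direction with chloro, methyl or an amine at this place, since fluoro and bromo are the only two groups compared there. Equally open, going by these compounds, is whether bromo would give a similar step at the place that carries fluoro in compound 1.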